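Amino for Methoxy on the Anilino Ring of Compound 3

The compounds below may be only part of what the source reports. "The series", "measured", "known", "first", "only" and "open" are said of these compounds alone.

Compound 3 `COc1ccc(Nc2nc3ccccc3nc2S(=O)(=O)c2ccc(Br)cc2)cc1` gives 1110 nM in a functional assay on PC-3 cells (Homo sapiens) for cytotoxicity, read by MTT assay, with a stated time of 72 h (on this read-out higher numbers stand for weaker inhibition and lower numbers for stronger inhibition), the lowest of the three numbers, though compound 2 sits within the usual scatter of it. Compound 2 `O=S(=O)(c1ccc(Br)cc1)c1nc2ccccc2nc1Nc1ccccc1` gives 1180 nM, and the step of a 1.1-fold lower number from compound 2 to compound 3 (0.03 log units; within the scatter) shows that adding the methoxy group changes little. Compound 1 `COc1ccc(S(=O)(=O)c2nc3ccccc3nc2Nc2ccc(N)cc2)cc1` gives 9640 nM. Compound 4 `Nc1ccc(Nc2nc3ccccc3nc2S(=O)(=O)c2ccc(Br)cc2)cc1` differs from compound 3 by amino in place of methoxy on an aromatic carbon. Among the compounds with values here, no measured step matches this change. Compound 1 carries the same amino group but differs from compound 3 in a second place too, so its value alone cannot separate the two changes. The step from compound 3 to compound 4 is expected to be a 2.3-fold higher number from compound 3 to compound 4 (0.35 log units; beyond the scatter), a mild rise. Compound 4 is estimated at 2500 nM, between 700 nM and 9000 nM.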

Compound 4, half-maximal inhibitory concentration: 2330 nM
Beside the measured number, compound 4's estimate is 1.1-fold (0.03 log units) above it, and the stated range covers the measured number.
By their numbers in this assay, from the lowest: compounds 3, 2 and 4 (each within the scatter of the next, the first and the last beyond it); then compound 1.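

In this assay, amino in place of methoxy gives a 2.1-fold higher number from compound 3 to compound 4 (0.32 log units; beyond the scatter) and so shows that this position, little changed by methoxy in place of hydrogen, does respond to the group placed there, if only modestly. Amino in place of hydrogen gives a 2.0-fold higher number from compound 2 to compound 4 (0.30 log units; within the scatter) and stays within the scatter. With the amino group held, bromo in place of methoxy at the second site gives a 4.1-fold lower number from compound 1 to compound 4 (0.62 log units; beyond the scatter) and shows that this second place also counts.

No available evidence explains these steps. On these data alone, how a carboxylic acid or a longer chain such as ethoxy would behave at the anilino position remains open.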